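Fluoro in place of bromo: expected cytotoxicity of compound 4

A few compounds are considered here, and "the series" means these few. Any claim that something is new, unique, unknown or untested is made for them only; others in the source may bear on it.

Measured in an ADME assay on HeLa cells (Homo sapiens) for cytotoxicity, read by microscopy; on this read-out higher numbers stand for lower toxicity in this test and lower numbers for higher toxicity in this test:
compound 1 `O=C(N/N=C/c1ccccc1)c1cccnc1` gives 100 ug/mL.
compound 2 `O=C(N/N=C/c1ccc(Cl)cc1)c1cccnc1` gives > 100 ug/mL, a limit of the assay.
compound 3 `O=C(N/N=C/c1ccc(Br)cc1)c1cccnc1` gives > 100 ug/mL, a limit of the assay.

Compound 3 therefore stands at the ceiling of the numbers shown, at the limit of > 100 ug/mL in this assay, at which 2 of the 3 values shown sit. Compound 4 `O=C(N/N=C/c1ccc(F)cc1)c1cccnc1` differs from it by fluoro in place of bromo on an aromatic carbon. For the measured compounds named here, the steps that bear on this change are those among the halogenated compounds: a number no lower from compound 1 to compound 3 (the limit leaves the size open), a number no lower from compound 1 to compound 2 (the limit leaves the size open) and a step that the two limits leave unreadable from compound 2 to compound 3. None of them shows a readable loss of tolerance on swapping one halogen for another or for hydrogen, so no step beyond the scatter is expected in this assay. Compound 4 is estimated at 100 ug/mL, between 50 ug/mL and 200 ug/mL, which means an expected a number no higher from compound 3 to compound 4 (the limit leaves the size open).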

Compound 4, minimum cytotoxic concentration: > 100 ug/mL
Compound 4: only a limit was reported; the forecaster's own chance of this, stated with the estimate: 60%; the middle value sits exactly at the limit.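

In this assay, fluoro on an aromatic carbon para to a large group now joins chloro and bromo at the same ceiling: the limit of > 100 ug/mL in this assay, at which 3 of the 4 values shown sit. Fluoro in place of hydrogen gives a number no lower from compound 1 to compound 4 (the limit leaves the size open) and behaves in this respect like the two heavier halogens. The steps among the three halogenated compounds cannot be read, so this assay puts fluoro, chloro and bromo in no order.

The compounds shown leave open how far the halogenated compounds lie past the limit. They also leave open whether an amine or a carboxylic acid at this position would reach the same ceiling.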